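Allyl to methyl on two weakly inhibiting cores

The source may hold more compounds than are shown below. What is called first, only, known or untested is meant among the compounds shown, and "the series" means these compounds.

Compound 1 `C=CCn1ncc2cnc(Cc3ccccc3)n2c1=O` and compound 3 `C=CCn1ncc2c(C)nc(C)n2c1=O` share an allyl group on a saturated chain carbon bound to an aromatic nitrogen; how their two cores differ is not broken down here. In a functional assay for inhibition, with Homo sapiens as the target (on this read-out higher numbers stand for weaker inhibition and lower numbers for stronger inhibition), compound 1 gives > 48000 nM, which is a limit of the assay and not a number. In this assay compound 3 gives 73000 nM. Compound 2 `Cc1nc(C)n2c(=O)n(C)ncc12` is compound 3 with hydrogen in place of vinyl on a saturated chain carbon bound to an aromatic nitrogen. In this assay compound 2 gives > 48000 nM, again a limit and not a number. For the measured compounds named here, the step that the limit leaves unreadable from compound 3 to compound 2 therefore cannot be read; the only thing the pair shows is that both values lie at or near (the limit of > 48000 nM in this assay, at which 2 of the 3 values shown sit).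

Compound 4 `Cn1ncc2cnc(Cc3ccccc3)n2c1=O` is compound 1 with the same change, (hydrogen in place of vinyl on a saturated chain carbon bound to an aromatic nitrogen), at the same place. The change occurs twice among these compounds, and in the one measured case it did not move the value away from the limit in a readable way. Compound 4 is accordingly expected to show only a small step, a step that the limit leaves unreadable from compound 1 to compound 4, resting on compound 1 already sitting at its limit of > 48000 nM and on the unreadable step that the limit leaves unreadable from compound 3 to compound 2. Compound 4 is expected at 80000 nM, with a range from 30000 nM to 250000 nM, and most likely to be reported only as a limit.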

Compound 4, half-maximal inhibitory concentration: > 48000 nM
Compound 4: a limit, no number; the forecaster's own chance of this, stated with the estimate: 75%; the middle value does not contradict the limit.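

In this assay compound 4 gives > 48000 nM, a limit and not a number. Compound 1 also stands at a limit, so no step from allyl to methyl can be read between compound 1 and compound 4: the limit of > 48000 nM in this assay, at which 3 of the 4 values shown sit.

The compounds shown leave open whether allyl to methyl changes inhibition at all on either core.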